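This account rests on a few compounds, and the source may have more. Where it says the series, first, only, none or still open, it means among the compounds named here.

Compound 1, `CC(C)C(C(N)=O)c1ccc(Cl)cc1`, gives only a limit in a functional assay on CHO cells for agonist activity at Free fatty acid receptor 2 (Homo sapiens), read by cAMP accumulation; a lower number here means a smaller maximal response, a higher number a larger maximal response: < 30%.
Compound 2, `CN1CCN(c2cnc(NC(=O)[C@H](c3ccc(Cl)cc3)C(C)(C)C)s2)CC1`, gives 113% in this assay.
Compound 3, `C[C@H](C(=O)Nc1nccs1)c1ccc(Cl)cc1`, gives 83% in this assay.

Of the two numbers recorded in this assay, compound 3 holds the lower one. Its nearest neighbour is compound 2, whose value lies higher by a margin beyond the usual scatter of the measurement. Compound 1 contributes no number for comparison, since its result is only (the limit of < 30% in this assay, at which 1 of the 3 values shown sits).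

The step under consideration leads from compound 3 to compound 4, `C=CC[C@H](C(=O)Nc1nccs1)c1ccc(Cl)cc1`. The difference between the two structures is vinyl in place of hydrogen on a saturated chain carbon, two bonds along the chain from an aromatic carbon and a carbonyl carbon. Among the measured compounds shown here, no measured pair in this set shows this kind of change, so nothing in the data fixes its size or direction. For the measured compounds named here, what the numbers do show is that compound 2, the only other compound with a number, sits above compound 3 in this assay, and that the maximal response in this set ranges from a limit up to a full response.

On that basis the step expected for compound 4 is a number 7 percentage points higher from compound 3 to compound 4 (within the scatter), a small upward movement that may well stay within the scatter. Compound 4 is therefore estimated to give 90% in this assay, with a likely range from 60% to 115%.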

Compound 4, largest response reached (reported as efficacy), in percent of the reference or control that the assay uses: 88%
Compound 4: middle estimate off by 2 percentage points, on the high side, and the stated range covers the measured number.
By their numbers in this assay, from the lowest: compounds 3 and 4 (each within the scatter of the next); then compound 2. At a limit, below all of these: compound 1.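

In this assay, among the compounds shown here, the step reads a number 5 percentage points higher from compound 3 to compound 4 (within the scatter), and it is the first measured step in this set, since the earlier compounds offered no pair differing in one place. It shows that on this saturated chain carbon, two bonds along the chain from an aromatic carbon and a carbonyl carbon, the change from methyl to allyl leaves the maximal response within the scatter, so this position accepts a longer unsaturated chain without a measurable loss of response. Nothing recorded here accounts for that outcome, and the one available note on the set, about the limit reached by compound 1, has no bearing on this step.

What the compounds shown leave open is how far this tolerance extends, since a single change at one position cannot show whether a longer saturated chain, a phenyl ring, or a chain ending in an amine or a carboxylic acid would keep the response. Compound 2 differs from compound 4 in more than one place, so it cannot show whether the allyl group would behave the same way on a different core.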